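The compounds below may be only part of what the source reports. "The series", "measured", "known", "first", "only" and "open" are said of these compounds alone.

Measured so far:
- compound 1 `CC[C@H](C)C(N)c1cc(C(F)(F)F)ccc1N1CCN(C(=O)CCc2ccc(Cl)cc2Cl)CC1`: 75 nM
- compound 2 `COc1cccc(CCC(=O)N2CCN(c3ccc(C(F)(F)F)cc3[C@@H](N)CC(C)C)CC2)c1`: 4000 nM
- compound 3 `CCC(C)[C@H](NCC1CCCO1)c1cc(C(F)(F)F)ccc1N1CCN(C(=O)CCc2ccc(Cl)cc2Cl)CC1`: 780 nM

These were tested in an assay on HEK293 cells for displacement of a labelled ligand from Melanocortin receptor 4 (Homo sapiens); on this read-out lower numbers stand for stronger inhibition and higher numbers for weaker inhibition. Among the three, compound 3 sits in the middle: compound 2 gives the highest number and compound 1 the lowest. Among the compounds with values here, the one comparison that bears on the next compound is a 10-fold higher number from compound 1 to compound 3 (1.02 log units; beyond the scatter), a large weakening when the free amine was substituted. Compound 4 `CCC(C)[C@H](NC(C)=O)c1cc(C(F)(F)F)ccc1N1CCN(C(=O)CCc2ccc(Cl)cc2Cl)CC1` goes further in the same direction: acetyl in place of (oxolan-2-yl)methyl on an amine nitrogen. Within the data shown here, with the basic nitrogen now turned into an amide, a further rise in this assay is expected, though no measured step shows how large. The step is estimated as a 3.8-fold higher number from compound 3 to compound 4 (0.59 log units; beyond the scatter), giving compound 4 an expected value of 3000 nM, within the range 800 nM to 12000 nM.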

Compound 4, inhibition constant: 360 nM
Beside the measured number, compound 4's estimate is 8.3-fold (0.92 log units) above it; measured number outside the range, below it.
By their numbers in this assay, from the lowest: compound 1; then compound 4; then compound 3; then compound 2.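

The two substituents on this amine nitrogen are not equivalent: acetyl in place of (oxolan-2-yl)methyl gives a 2.2-fold lower number from compound 3 to compound 4 (0.34 log units; beyond the scatter), so substitution here need not cost as much as the first step suggested. Even so, the free amine remains ahead of the acetamide, with a 4.8-fold higher number from compound 1 to compound 4 (0.68 log units; beyond the scatter). No available evidence accounts for the difference between the two substituents. Still open, from the compounds shown here alone, is how a plain methyl group, or a longer acyl chain such as butanoyl, would fare on this nitrogen.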